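Adding a methoxy group to compound 3

The source may report more compounds than this note shows. Statements on the series, on what has been measured and on what is new or still open speak of the compounds shown alone.

compound 1 `COc1cc(/C=C/C(=O)/C=C/c2cccc3ccccc23)ccc1OCc1cn(CCOc2cc(=O)oc3ccccc23)nn1`: 83%
compound 2 `COc1ccccc1/C=C/C(=O)/C=C/c1ccc(OCc2cn(CCCOc3cc(=O)oc4ccccc34)nn2)c(OC)c1`: 53%
compound 3 `COc1cc(/C=C/C(=O)/C=C/c2ccccc2)ccc1OCc1cn(CCCCOc2cc(=O)oc3ccccc23)nn1`: 34%

All three compounds were tested in a functional assay on HCT-116 cells (Homo sapiens) for inhibition, read by sulforhodamine B assay, with a stated time of 48 h, tested at 50 uM (a higher number here means more inhibition of growth at the concentration tested, a lower number less inhibition of growth), and they spread widely. Compound 3 at 34% stands lowest of the three, while compound 2 gives 53% and compound 1 gives 83%. The gaps from compound 3 to each of the other two lie beyond the scatter.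

The next compound is compound 4 `COc1ccccc1/C=C/C(=O)/C=C/c1ccc(OCc2cn(CCCCOc3cc(=O)oc4ccccc34)nn2)c(OC)c1` and it differs from compound 3 in a single place (methoxy in place of hydrogen on an aromatic carbon): methoxy in place of hydrogen on an aromatic carbon, ortho to a large group, so that phenyl becomes 2-methoxyphenyl. Within the data shown here, no two measured compounds differ in only one place, so the size of this change has not been seen directly. Among the measured compounds shown here, the sole guide is that the 2-methoxyphenyl group also occurs in compound 2 at 53% although that compound differs from compound 3 elsewhere as well. The step expected is a number 11 percentage points higher from compound 3 to compound 4 (beyond the scatter) in the upward direction, and it is expected to lie only slightly beyond the scatter at best. For compound 4 the estimated value is 45% with an expected range from 28% at the lower end to 62% at the upper end.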

Compound 4, percent growth inhibition at one concentration: 43%
Compound 4: the middle estimate sits 2 percentage points above what was measured; the measured number falls inside the stated range.
By their numbers in this assay, from the lowest: compounds 3, 4 and 2 (each within the scatter of the next, the first and the last beyond it); then compound 1.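

Among these compounds, compound 3 and compound 4 give the first direct reading of this change, since none of the earlier compounds differed in only one place. In this assay the step is a number 9 percentage points higher from compound 3 to compound 4 (within the scatter) and so, with the butyl-length chain and the rest of the structure held constant, methoxy in place of hydrogen on an aromatic carbon, ortho to a large group, does not separate the two compounds. Nothing available explains the size of this step.

On these data alone, the pair speaks only for phenyl becoming 2-methoxyphenyl on this one background, so it remains open whether a hydroxy group, a fluorine atom or a dimethylamino group in the same place would give a step beyond the scatter. As far as these compounds go, it is also open whether the same methoxy change would read alike with a shorter chain, which would need the phenyl partner of compound 2 for a direct comparison.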